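A few compounds are considered here, and "the series" means these few. Any claim that something is new, unique, unknown or untested is made for them only; others in the source may bear on it.

Series notes. In a functional assay on A375-C5 cells (Homo sapiens) for inhibition, read by sulforhodamine B assay, with a stated time of 48 h (on this read-out higher numbers stand for weaker inhibition of growth and lower numbers for stronger inhibition of growth), compound 3 `COC(=O)c1sc2cc(C#Cc3ccccc3N)cnc2c1N` gives 3100 nM, the lowest of the two numbers in hand. Compound 1 `COC(=O)c1sc2cc(C#Cc3cccc(N)c3)cnc2c1N` gives 11600 nM, and the step of a 3.7-fold lower number from compound 1 to compound 3 (0.57 log units; beyond the scatter) is modest. Compound 2 `COC(=O)c1sc2cc(C#Cc3ccccc3OC)cnc2c1N` reaches only > 47300 nM; that is a limit of this assay, not a number. The step of an at least 15-fold lower number from compound 2 to compound 3 (1.18 log units; beyond the scatter) is large, though it rests on that limit (the limit of > 47300 nM in this assay, at which 1 of the 3 values shown sits). Compound 4 `COC(=O)c1sc2cc(C#Cc3ccccc3)cnc2c1N` differs from compound 3 by hydrogen in place of amino on an aromatic carbon. Going by the values given here, no measured step removes the amino outright; the nearest are the move from 3-aminophenyl to 2-aminophenyl, a 3.7-fold lower number from compound 1 to compound 3 (0.57 log units; beyond the scatter), and the swap of methoxy for amino on the aromatic carbon, an at least 15-fold lower number from compound 2 to compound 3 (1.18 log units; beyond the scatter), both of which leave compound 3 with the lowest number. The expectation is therefore a step toward weaker inhibition, a 3.9-fold higher number from compound 3 to compound 4 (0.59 log units; beyond the scatter), beyond the scatter but short of the limit. Compound 4 is estimated at 12000 nM, with a range of 4000 nM to 40000 nM.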

Compound 4, concentration for 50% growth inhibition: > 150000 nM
Compound 4 ended at the assay's limit; the forecaster's own chance of this, stated with the estimate: 15%; middle value at least 12-fold (1.09 log units) away from the limit.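

In this assay compound 4 gives > 150000 nM, which is a limit of the assay and not a number: the limit of > 150000 nM in this assay, at which 1 of the 4 values shown sits. Loss of the amino from the aromatic carbon is a large change at this position, an at least 48-fold higher number from compound 3 to compound 4 (1.68 log units; beyond the scatter), and the other amino-bearing compound also separates from the bare phenyl, an at least 12-fold higher number from compound 1 to compound 4 (1.11 log units; beyond the scatter). The earlier compounds compared only where the amino sat and its swap for methoxy; here measurable growth inhibition among the compounds shown goes only with an amino on the phenyl, and the methoxy compound, compound 2, also ends at a limit, so the step between compound 2 and compound 4 cannot be read. On these data alone, whether a hydroxyl or a dimethylamino group at this place would keep any of the inhibition stays open.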